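The source may report more compounds than this note shows. Statements on the series, on what has been measured and on what is new or still open speak of the compounds shown alone.

Working notes on the hydrazone series. Compound 2 `N#Cc1ccc(/C=N/Nc2nc(N)c3ncn([C@@H]4O[C@H](CO)[C@@H](O)[C@H]4O)c3n2)cc1` carries a 4-cyanophenyl on the carbon with a double bond to nitrogen; in an assay on CHO-K1 cells for displacement of a labelled ligand from adenosine receptor A1 (Homo sapiens), read by scintillation counting, with a stated time of 60 min (on this read-out higher numbers stand for weaker inhibition and lower numbers for stronger inhibition), compound 2 gives 4.1 nM. Compound 1 `Nc1nc(N/N=C/c2ccc(Cl)c(C(F)(F)F)c2)nc2c1ncn2[C@@H]1O[C@H](CO)[C@@H](O)[C@H]1O` returns in this assay only a limit of the assay, > 10000 nM. Among the compounds with values here, compound 2 therefore stands as the only true number in the set; the other entry is a limit, namely (the limit of > 10000 nM in this assay, at which 1 of the 2 values shown sits). Within the data shown here, the step of an at least 2400-fold lower number from compound 1 to compound 2 (3.38 log units; beyond the scatter) is the single measured step, and it is large. Compound 3 `CCCCc1nc(/C=N/Nc2nc(N)c3ncn([C@@H]4O[C@H](CO)[C@@H](O)[C@H]4O)c3n2)c(Cl)[nH]1` is not yet measured. Against compound 2 the change is 2-butyl-5-chloro-1H-imidazol-4-yl in place of 4-cyanophenyl on a carbon with a double bond to nitrogen. Among the measured compounds shown here, the one measured step concerns the same carbon and shows that the group there can move the inhibition constant from a limit to a small number, but it offers no reading for an imidazole in that place, so the direction from compound 2 cannot be fixed from the data. A step of a 73-fold higher number from compound 2 to compound 3 (1.86 log units; beyond the scatter) is expected, toward weaker inhibition. For compound 3 an inhibition constant of 300 nM is estimated, within 20 nM to 5000 nM.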

Compound 3, inhibition constant: 12 nM
The estimate for compound 3 lay 25-fold (1.40 log units) above the measured number; the whole stated range lies above it.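

In this assay, the place on a carbon with a double bond to nitrogen is not tied to a six-membered aromatic ring of carbon only: the 2-butyl-5-chloro-1H-imidazol-4-yl group stays close to the 4-cyanophenyl group, with a 2.9-fold higher number from compound 2 to compound 3 (0.47 log units; beyond the scatter), a step that is small beside the one seen earlier but still beyond the scatter. Chlorine on the group at this place does not by itself go with the loss seen for the 4-chloro-3-(trifluoromethyl)phenyl group, as the imidazole also carries a chlorine and gives an at least 830-fold lower number from compound 1 to compound 3 (2.92 log units; beyond the scatter). The size of that step is only a lower bound, since compound 1 gives a limit of the assay and not a number: the limit of > 10000 nM in this assay, at which 1 of the 3 values shown sits.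

As far as these compounds go, how much of the low number of compound 3 belongs to the butyl chain, the chlorine or the imidazole ring itself stays open, as all three change together. An imidazol-4-yl group with a methyl in place of the butyl chain, or with an amine in place of the chlorine, would separate these parts.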